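Cyclopropyl to cyclobutyl on an amide-type nitrogen

The source may hold more compounds than are shown below. What is called first, only, known or untested is meant among the compounds shown, and "the series" means these compounds.

- Compound 1 `Cn1ncc(Cl)c1-c1cc(C(=O)N[C@@H]2CN[C@H](CC(O)CO)C[C@H]2c2ccc(Cl)c(Cl)c2)oc1Cl`: 70 nM
- Compound 2 `Cn1ncc(Cl)c1-c1cc(C(=O)N[C@@H]2CN[C@H](CC(=O)NC3CC3)C[C@H]2c2ccc(Cl)c(Cl)c2)oc1Cl`: 190 nM

Both values come from a functional assay on LNCaP cells (Homo sapiens) for antiproliferative activity; on this read-out lower numbers stand for stronger inhibition and higher numbers for weaker inhibition. Compound 2, at 190 nM, has the higher of the two numbers, so it is the weaker inhibitor of this pair. Compound 3 `Cn1ncc(Cl)c1-c1cc(C(=O)N[C@@H]2CN[C@H](CC(=O)NC3CCC3)C[C@H]2c2ccc(Cl)c(Cl)c2)oc1Cl` keeps the whole structure of compound 2 except for one small ring: cyclobutyl in place of cyclopropyl on an amide-type nitrogen. In words, cyclobutyl takes the place of cyclopropyl on an amide-type nitrogen.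

For the measured compounds named here, only one measured step is available, a 2.7-fold higher number from compound 1 to compound 2 (0.43 log units; beyond the scatter). It is modest but beyond the scatter. In that step, cyclopropylcarbamoyl replaces 1,2-dihydroxyethyl, a much larger change than the one at hand. Going by the values given here, it shows how far a change in this part of the molecule has moved the number once, but no measured pair tests ring size alone. The data therefore suggest no direction, and no step beyond the scatter is expected in this assay. The estimated change is a 1.1-fold lower number from compound 2 to compound 3 (0.02 log units; within the scatter). For compound 3, the expected value is 180 nM, within an estimated range of 80 nM to 400 nM.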

Compound 3, half-maximal inhibitory concentration: 80 nM
Compound 3: the middle estimate sits 2.3-fold (0.35 log units) above what was measured; low and high end bracket the measured number.
By their numbers in this assay, from the lowest: compounds 1 and 3 (each within the scatter of the next); then compound 2.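

In this assay, the ring on the amide-type nitrogen matters by itself: with cyclobutyl in place of cyclopropyl, the data show a 2.4-fold lower number from compound 2 to compound 3 (0.38 log units; beyond the scatter) for the gain of a single ring carbon. This modest step is beyond the scatter, as is a 2.7-fold higher number from compound 1 to compound 2 (0.43 log units; beyond the scatter) even though that earlier change replaces a much larger part of the side chain, so a small edit at this position can shift the number measurably. The comparison with the 1,2-dihydroxyethyl group also changes, since the data give a 1.1-fold higher number from compound 1 to compound 3 (0.06 log units; within the scatter) and this lies within the scatter, which means the higher number of compound 2 does not hold for every carbamoyl side chain.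

Two ring sizes cannot show whether the number would keep falling with cyclopentyl or cyclohexyl, or how an open chain such as isopropyl or a ring carrying an amine would compare on the same amide nitrogen. Cyclobutyl gives a lower number than cyclopropyl in this pair. No measurement shown here bears on what lies behind that difference.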